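From 3-nitrophenyl to 4-aminophenyl: working notes on compound 3

The compounds below may be only part of what the source reports. "The series", "measured", "known", "first", "only" and "open" are said of these compounds alone.

compound 1 `COc1cc(C(=O)c2cn(-c3ccccc3)cc2-c2ccc(N)cc2)cc(OC)c1OC`: 9 nM
compound 2 `COc1cc(C(=O)c2cn(-c3ccc(N)cc3)cc2-c2cccc([N+](=O)[O-])c2)cc(OC)c1OC`: 260 nM

In a functional assay on MCF7 cells (Homo sapiens) for cytotoxicity, read by MTT assay, with a stated time of 96 h (a lower number here means a stronger inhibitor, a higher number a weaker inhibitor), compound 2 gives 260 nM as the higher of the two numbers, and its gap to compound 1 lies beyond the scatter. Among the measured compounds shown here, these two compounds differ in more than one place, so the data hold no step for a single change. The next compound, compound 3 `COc1cc(C(=O)c2cn(-c3ccc(N)cc3)cc2-c2ccc(N)cc2)cc(OC)c1OC`, remains unmeasured. Compared with compound 2, it has 4-aminophenyl in place of 3-nitrophenyl on an aromatic carbon. The same 4-aminophenyl group stands at that place in compound 1, which gives 9 nM as the lower number. Compound 3 also keeps the other 4-aminophenyl group of compound 2, which compound 1 lacks, and the data do not show what that group alone contributes. A fall in the number beyond the scatter is therefore expected, with an estimated 13-fold lower number from compound 2 to compound 3 (1.11 log units; beyond the scatter) in this assay as a stronger result. The estimate for compound 3 is 20 nM with an expected range from 6 nM to 70 nM for four of five measurements.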

Compound 3, half-maximal inhibitory concentration: 15 nM
Beside the measured number, compound 3's estimate is 1.3-fold (0.12 log units) above it; low and high end bracket the measured number.
By their numbers in this assay, from the lowest: compounds 1 and 3 (each within the scatter of the next); then compound 2.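

In this assay, among the compounds shown here, 4-aminophenyl in place of 3-nitrophenyl at this position, next to the ring atom that bears a large group, gives a 17-fold lower number from compound 2 to compound 3 (1.24 log units; beyond the scatter) as the first single-place step, and it is a large one. The other change now readable, amino in place of hydrogen on an aromatic carbon, gives a 1.7-fold higher number from compound 1 to compound 3 (0.22 log units; within the scatter) and so stays within the scatter: the second 4-aminophenyl group, whose contribution could not be read from the earlier pair, leaves no effect that can be told apart from repeat variation in this assay. For the compounds shown here, nothing measured so far accounts for the size of the large step.

That step changes both the substituent on the phenyl ring and where it stands, and the compounds shown do not separate the two; a 3-aminophenyl or a 4-nitrophenyl group at the same place would do so. Also open, on these data alone, is whether the amino group itself matters at this position or whether a hydroxyl or a methoxy group there would give a similar number.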